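A few compounds are considered here, and "the series" means these few. Any claim that something is new, unique, unknown or untested is made for them only; others in the source may bear on it.

Compound 1 (`C=C(C)[C@@H]1CC[C@](C)(O)[C@H]1/C=C/C(C)=C/[C@@H]1C[C@@]23[C@H](OCCC[C@@H]2/C(=C(/C)C=O)CC[C@]3(C)O)O1`) and compound 2 (`C=C(C)[C@@H]1CC[C@](C)(O)[C@H]1/C=C/C(C)=C/[C@@H]1C[C@@]23[C@H](OCCC[C@@H]2/C(=C(\C)C=O)CC[C@]3(C)O)O1`) share the same atoms and bonds, and compound 3 (`C=C(C)[C@H]1CC[C@@](C)(O)[C@@H]1/C=C/C(C)=C/[C@@H]1C[C@@]23[C@H](OCCC[C@@H]2/C(=C(/C)C=O)CC[C@]3(C)O)O1`) has yet to be tested. In a functional assay on HCT-116 cells (Homo sapiens) for cytotoxicity, read by MTT assay, with a stated time of 72 h (a lower number here means a stronger inhibitor, a higher number a weaker inhibitor), compound 1 gives > 10000 nM as a limit of the assay and not a number. Compound 2 gives > 10000 nM as a limit too, so its standing is known only as a limit. The change from compound 2 to compound 3 is one of configuration alone (the two compounds have the same atoms and bonds and differ only in configuration as drawn: 4 of 11 stereo elements differ; a stereocentre at a saturated ring carbon is drawn R in compound 2 and S in compound 3; a stereocentre at a saturated ring carbon is drawn S in compound 2 and R in compound 3; a stereocentre at a saturated ring carbon is drawn S in compound 2 and R in compound 3; a double bond is drawn E in compound 2 and Z in compound 3) with nothing leaving and nothing entering. For the measured compounds named here, the one measured step that bears on it is also a change of configuration at a double bond (a step that the two limits leave unreadable from compound 1 to compound 2) and rests on the fact that compounds 1 and 2 differ only in the configuration as drawn in the structures. Its size cannot be read because of the limit of > 10000 nM in this assay, at which 2 of the 2 values shown sit, in the data. Since compound 2 shows > 10000 nM as a limit, no step beyond the scatter is expected in this assay and no direction can be named. The expected outcome is a step that the limit leaves unreadable from compound 2 to compound 3 in this estimate. For compound 3 the estimate is 15000 nM with an expected range from 6000 nM to 40000 nM and a limit as the likeliest report.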

Compound 3, half-maximal inhibitory concentration: > 10000 nM
Compound 3 was reported as a limit (the forecaster's own chance of this, stated with the estimate: 85%); the middle value lies beyond the limit too.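

In this assay compound 3 gives > 10000 nM, a limit of the assay and not a number. For the compounds shown here, compound 1 and compound 2 are also reported only as limits, and no step among the three compounds can be read. The compounds shown leave open whether the double bond or the saturated ring stereocentres affect the read-out in this assay at all.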